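This account rests on a few compounds, and the source may have more. Where it says the series, first, only, none or still open, it means among the compounds named here.

Measured so far:
compound 1, `O=Cc1ccc(-c2cn3ccnc3c(-c3ccc4ncn(C5CCCCC5)c4c3)n2)cc1`, gives 23%;
compound 2, `CCc1ccc(-c2cn3ccnc3c(-c3ccc4ncn(Cc5ccccc5)c4c3)n2)cc1`, gives 36.4%.

Both were tested in a functional assay on M14 cells (Homo sapiens) for inhibition, read by sulforhodamine B assay, with a stated time of 48 h, tested at 10 uM; a lower number here means less inhibition, a higher number more inhibition at the concentration tested (going by the name of the read-out). Compound 2 stands highest of the two numbers, and its nearest neighbour, compound 1, sits lower by more than the usual scatter. The next compound, compound 3, `O=Cc1ccc(-c2cn3ccnc3c(-c3ccc4ncn(Cc5ccccc5)c4c3)n2)cc1`, is not yet measured. Relative to compound 2 it shows one change, (formyl in place of ethyl on an aromatic carbon). Compound 1 also carries a formyl group, and its value gives a hint that this group does not raise inhibition here. A modest step downward, a number 9.4 percentage points lower from compound 2 to compound 3 (within the scatter), is expected. Compound 3 is therefore estimated at 27%, within 10% to 44%.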

Compound 3, a percentage reported as inhibition, at one concentration (the size of the read-out at that concentration, not a potency): 23%
Beside the measured number, compound 3's estimate is 4 percentage points above it; the measured number falls inside the stated range.
By their numbers in this assay, from the lowest: compounds 1 and 3 (each within the scatter of the next); then compound 2.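

In this assay, 4-formylphenyl in place of 4-ethylphenyl gives a drop beyond the scatter (a number 13.4 percentage points lower from compound 2 to compound 3 (beyond the scatter)), so the group at this place on the aromatic ring does matter to the read-out. With formyl in place, benzyl and cyclohexyl on the aromatic nitrogen cannot be told apart (no change at the digits printed from compound 1 to compound 3 (within the scatter)). Nothing at hand explains the drop. On these data alone, whether an amine, a carboxylic acid or a longer chain at this place would go above or below ethyl remains open. So does whether cyclohexyl and benzyl would also match with ethyl in place of formyl.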